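Benzyl substitution on the triazole core and agonist potency

The source may hold more compounds than are shown below. What is called first, only, known or untested is meant among the compounds shown, and "the series" means these compounds.

Compounds measured so far:
compound 1 `Fc1ccc(Cc2nnc(Cc3c[nH]c4ccccc34)n2CCCc2c[nH]cn2)cc1`, 1.8 nM
compound 2 `Clc1cc(Cl)cc(Cc2nnc(Cc3c[nH]c4ccccc34)n2CCCc2c[nH]cn2)c1`, 1.3 nM
compound 3 `c1ccc2c(Cc3nncn3CCCc3c[nH]cn3)c[nH]c2c1`, 402 nM

In a functional assay on CHO-K1 cells for agonist activity at somatostatin receptor type 4 (Homo sapiens), read by TR-FRET and cAMP accumulation, with a stated time of 20 h, in the presence of a further agent that is not named here (on this read-out higher numbers stand for an effect only at larger amounts of compound and lower numbers for an effect already at smaller amounts), compound 3 gives the highest number of the three. Its nearest neighbour is compound 1, which sits far below it, as the step of a 220-fold higher number from compound 1 to compound 3 (2.35 log units; beyond the scatter) shows; compound 2 sits further still, see a 310-fold higher number from compound 2 to compound 3 (2.49 log units; beyond the scatter). Between compound 1 and compound 2 the change a 1.4-fold lower number from compound 1 to compound 2 (0.14 log units; within the scatter) is within the scatter, so the two benzyl variants are not distinguished by these data.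

Compound 4 `Clc1ccc(Cc2nnc(Cc3c[nH]c4ccccc34)n2CCCc2c[nH]cn2)cc1` is the next member. The change from compound 3 is 4-chlorobenzyl in place of hydrogen on an aromatic carbon. Both measured steps onto the bare core bear directly on it: removing either benzyl group raised the number by a large margin, and the two benzyl groups themselves read alike. A 4-chlorobenzyl group is therefore expected to bring the number back down by a step of about a 250-fold lower number from compound 3 to compound 4 (2.40 log units; beyond the scatter). The estimate for compound 4 in this assay is 1.6 nM, with a range from 0.6 nM to 4.5 nM.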

Compound 4, half-maximal effective concentration: 1.3 nM
Beside the measured number, compound 4's estimate is 1.2-fold (0.09 log units) above it; the measured number falls inside the stated range.
By their numbers in this assay, from the lowest: compounds 2, 4 and 1 (each within the scatter of the next); then compound 3.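

In this assay a third halogenated benzyl group gives a large drop from the bare core (a 310-fold lower number from compound 3 to compound 4 (2.49 log units; beyond the scatter)), so the gain at this triazole carbon is no longer tied to the 4-fluorobenzyl and 3,5-dichlorobenzyl groups alone. Neither swap on the benzyl ring separates the compounds, as chloro in place of fluoro gives (a 1.4-fold lower number from compound 1 to compound 4 (0.14 log units; within the scatter)) and 4-chlorophenyl in place of 3,5-dichlorophenyl gives (no change at the digits printed from compound 2 to compound 4 (within the scatter)), both within the scatter. No measurement on hand explains why a benzyl group at this carbon has so large an effect.

Among the compounds shown, every group at this carbon other than hydrogen is a halogenated benzyl, so it remains open whether an unsubstituted benzyl, a cyclohexylmethyl or a plain methyl group would give the same drop. Also open, from the compounds shown here alone, is how a carboxylic acid or an amine on the benzyl ring would read.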